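Swapping the 4-Bromophenyl Group of Compound 1

The source may report more compounds than this note shows. Statements on the series, on what has been measured and on what is new or still open speak of the compounds shown alone.

Compound 1 `O=C1O[C@H]([C@@H](O)Cn2cc(-c3ccc(Br)cc3)nn2)C(OCc2ccccc2)=C1OCc1ccccc1` carries a 4-bromophenyl group on the five-membered aromatic ring with 3 nitrogen. In a functional assay on CFPAC-1 cells (Homo sapiens) for antiproliferative activity, read by MTT assay, with a stated time of 72 h (a lower number here means a stronger inhibitor, a higher number a weaker inhibitor), compound 1 gives 5830 nM. Compound 2 `Cc1ccc(-c2cn(C/C=C3\OC(=O)C(OCc4ccccc4)=C3OCc3ccccc3)nn2)cc1` reaches only a limit of the assay, > 100000 nM. Compound 3 `O=C1O/C(=C\Cn2cc(-c3cc(C(F)(F)F)cc(C(F)(F)F)c3)nn2)C(OCc2ccccc2)=C1OCc1ccccc1` likewise reaches only a limit, > 100000 nM. Within the data shown here, compound 1 thus holds the only true number in this set, while the other two sit at the limit of > 100000 nM in this assay, at which 2 of the 3 values shown sit. Compound 4 `O=C1O[C@H]([C@@H](O)Cn2cc(CNS(=O)(=O)c3ccc(Cl)cc3)nn2)C(OCc2ccccc2)=C1OCc1ccccc1` differs from compound 1 by a single change, ((((4-chlorophenyl)sulfonyl)amino)methyl in place of 4-bromophenyl on an aromatic carbon). Among the measured compounds shown here, no step between measured compounds is available to guide the size of this change; a shift somewhat beyond the scatter toward weaker inhibition seems most likely, though a shift the other way cannot be ruled out. Compound 4 is expected to give 12000 nM, within 2500 nM to 45000 nM. This estimate means an expected step of a 2.1-fold higher number from compound 1 to compound 4 (0.31 log units; beyond the scatter).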

Compound 4, half-maximal inhibitory concentration: 38900 nM
Compound 4: middle estimate off by 3.2-fold (0.51 log units), on the low side, and the stated range covers the measured number.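

This position on the five-membered aromatic ring with 3 nitrogen responds to the group it carries: in this assay, the swap gives a 6.7-fold higher number from compound 1 to compound 4 (0.82 log units; beyond the scatter). Even so, compound 4 keeps a true number rather than a limit, so the larger sulfonyl-bearing group does not remove all measurable activity. Nothing shown here explains the weakening.

Which part of the new group goes with the change stays open. A 4-chlorophenyl group or a plain aminomethyl group on the same carbon would help separate the parts.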